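Adding a Methyl to the Anilino Ring of Compound 2

The source may report more compounds than this note shows. Statements on the series, on what has been measured and on what is new or still open speak of the compounds shown alone.

Three compounds sharing one core are compared in a functional assay on MGC-803 cells (Homo sapiens) for inhibition, read by MTT assay, with a stated time of 72 h; a higher number here means a weaker inhibitor, a lower number a stronger inhibitor. Compound 1 `O=C(CSc1nc(Nc2ccccc2)c2ccccc2n1)Nc1ccccc1Cl` gives 24800 nM. Compound 2 `C=CC(=O)Nc1cccc(NC(=O)CSc2nc(Nc3ccccc3)c3ccccc3n2)c1` gives 7310 nM, the lowest of the three numbers. Compound 3 `O=C(CSc1nc(Nc2ccccc2)c2ccccc2n1)Nc1ccc(Cl)cc1` gives 40400 nM. The step of a 3.4-fold lower number from compound 1 to compound 2 (0.53 log units; beyond the scatter) and the step of a 5.5-fold higher number from compound 2 to compound 3 (0.74 log units; beyond the scatter) both lie beyond the scatter, so compound 2 stands clearly apart from both of its neighbours, while the step of a 1.6-fold higher number from compound 1 to compound 3 (0.21 log units; within the scatter) lies within the scatter, so compound 1 and compound 3 cannot be told apart.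

Compound 4 `C=CC(=O)Nc1cccc(NC(=O)CSc2nc(Nc3ccccc3C)c3ccccc3n2)c1` keeps everything in compound 2 and alters only the anilino ring: methyl in place of hydrogen on an aromatic carbon. Within the data shown here, every measured step here changes the aryl group on the amide-type nitrogen; none touches the anilino ring, so no measured step bears directly on this change. Among the measured compounds shown here, the only loose guide is that moving a small substituent to another spot on a ring, as between compound 1 and compound 3, shifted the number only within the scatter. For the measured compounds named here, with no direct precedent, the expected step of a 1.0-fold higher number from compound 2 to compound 4 (0.01 log units; within the scatter) is none beyond the scatter, in either direction. Compound 4 is therefore estimated at 7500 nM, with a range from 2500 nM to 22000 nM.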

Compound 4, half-maximal inhibitory concentration: 30200 nM
The estimate for compound 4 lay 4.0-fold (0.60 log units) below the measured number; the measured number lies above the stated range.
By their numbers in this assay, from the lowest: compound 2; then compounds 1, 4 and 3 (each within the scatter of the next).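

In this assay, the anilino ring proves not to be a silent part of the molecule: going from phenyl to 2-methylphenyl gives a 4.1-fold higher number from compound 2 to compound 4 (0.62 log units; beyond the scatter), even though the change adds only 1 heavy atom, a single carbon. Among these compounds, every earlier step changed the aryl group on the amide-type nitrogen, so this is the first sign that the number also responds to a change on the anilino ring, and here that change gives a weaker inhibitor. No measurement available here accounts for this step, so it stands as an observation without an explanation.

Only one group at one place on this ring is shown, so it remains unclear whether the shift belongs specifically to a methyl ortho to a large group or would follow other substituents on the ring. On these data alone, a methyl elsewhere on the ring, or a fluorine, a methoxy or an amine in the same place, would help separate these readings, and it also remains open whether the methyl would have a similar effect with the 2-chlorophenyl group of compound 1 on the amide-type nitrogen.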